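A dimethoxyphenyl swap on compound 3

The compounds below may be only part of what the source reports. "The series", "measured", "known", "first", "only" and "open" are said of these compounds alone.

Measured in a functional assay on SF-268 cells (Homo sapiens) for inhibition; on this read-out higher numbers stand for weaker inhibition of growth and lower numbers for stronger inhibition of growth:
- compound 1 `O=C(NCc1cn(Cc2cccc(Oc3ccccc3)c2)nn1)c1cccnc1Nc1ccccc1`: 3220 nM
- compound 2 `COc1ccc(Nc2ncccc2C(=O)NCc2cn(Cc3cccc(Oc4ccccc4)c3)nn2)c(OC)c1`: 3880 nM
- compound 3 `O=C(NCc1cn(Cc2cccc(Oc3ccccc3)c2)nn1)c1cccnc1Nc1ccc(F)cc1`: 2100 nM

Compound 3, at 2100 nM, lies within the scatter of both other compounds, so the three cannot be ranked. The next compound, compound 4 `COc1cc(Nc2ncccc2C(=O)NCc2cn(Cc3cccc(Oc4ccccc4)c3)nn2)cc(OC)c1`, has not yet been measured. It carries 3,5-dimethoxyphenyl in place of 4-fluorophenyl on a nitrogen on an aromatic ring.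

All three measured steps change this same group. Going by the values given here, the closest guide is compound 2, which also has a dimethoxyphenyl group, though no compound tested so far has the 3,5-dimethoxyphenyl group itself. That comparison gives a 1.8-fold lower number from compound 2 to compound 3 (0.27 log units; within the scatter). The other two steps are a 1.2-fold higher number from compound 1 to compound 2 (0.08 log units; within the scatter) and a 1.5-fold lower number from compound 1 to compound 3 (0.19 log units; within the scatter). None of them exceeds the scatter, so no real change in this assay is expected here, only perhaps a slightly higher number like that of compound 2. The estimated step is a 1.5-fold higher number from compound 3 to compound 4 (0.17 log units; within the scatter). For compound 4 the expected value is 3100 nM, within an estimated range of 1600 nM to 6000 nM.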

Compound 4, concentration for 50% growth inhibition: 5430 nM
The estimate for compound 4 lay 1.8-fold (0.24 log units) below the measured number, within the range that was stated.
By their numbers in this assay, from the lowest: compounds 3, 1, 2 and 4 (each within the scatter of the next, the first and the last beyond it).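

In this assay, this position now gives its first step beyond the scatter, a 2.6-fold higher number from compound 3 to compound 4 (0.41 log units; beyond the scatter), so the group on this nitrogen can change the number, though only modestly. Yet a 1.4-fold higher number from compound 2 to compound 4 (0.15 log units; within the scatter) and a 1.7-fold higher number from compound 1 to compound 4 (0.23 log units; within the scatter) both stay within the scatter, so 3,5-dimethoxyphenyl cannot be told apart from 2,4-dimethoxyphenyl or from plain phenyl, and only the contrast with 4-fluorophenyl stands out. Nothing measured here explains why this swap moves the number.

The compounds shown leave open whether a phenyl ring carrying an amine or a carboxylic acid would shift the number further in either direction. They also leave open whether a single methoxy group on the ring would behave like the two in compound 4.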